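Aryl variation on the saturated ring carbon

This account rests on a few compounds, and the source may have more. Where it says the series, first, only, none or still open, it means among the compounds named here.

Measured compounds:
compound 1 `CNC(=O)c1cc(Oc2ccc(C3=NNC(c4ccc(Cl)cc4Cl)C3)cc2)ccn1`; in a functional assay on A549 cells (Homo sapiens) for cytotoxicity, read by MTT assay, with a stated time of 72 h (on this read-out lower numbers stand for stronger inhibition and higher numbers for weaker inhibition), compound 1 gives 6930 nM
compound 2 `CNC(=O)c1cc(Oc2ccc(C3=NNC(c4ccc([N+](=O)[O-])cc4)C3)cc2)ccn1`; in this assay compound 2 gives 19500 nM
compound 3 `CNC(=O)c1cc(Oc2ccc(C3=NNC(c4cccc([N+](=O)[O-])c4)C3)cc2)ccn1`; in this assay compound 3 gives "not determined" (no result reported)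

Compound 3 has no number in this assay, so it cannot be placed among the measured values. Compound 4 `CNC(=O)c1cc(Oc2ccc(C3=NNC(c4ccc(OC)cc4)C3)cc2)ccn1` differs from it by 4-methoxyphenyl in place of 3-nitrophenyl on a saturated ring carbon. Within the data shown here, the only measured step at this saturated ring carbon, a 2.8-fold higher number from compound 1 to compound 2 (0.45 log units; beyond the scatter), exchanges two other groups and does not map onto this change; no measured step bears directly on it, and the direction cannot be inferred. The expectation therefore rests on the spread of the values of compound 1 and compound 2. Compound 4 is expected in this assay to give about 11000 nM, within a range of 3000 nM to 40000 nM.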

Compound 4, half-maximal inhibitory concentration: 13100 nM
Compound 4: middle estimate off by 1.2-fold (0.08 log units), on the low side; the range from low to high includes it.
By their numbers in this assay, from the lowest: compounds 1, 4 and 2 (each within the scatter of the next, the first and the last beyond it).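

In this assay, 4-methoxyphenyl on the saturated ring carbon sits within the scatter of both earlier aryl groups (a 1.5-fold lower number from compound 2 to compound 4 (0.17 log units; within the scatter); a 1.9-fold higher number from compound 1 to compound 4 (0.28 log units; within the scatter)). Methoxy in place of nitro on the aromatic carbon thus gives no separable change, and only compound 1 and compound 2 stay apart beyond the scatter. Nothing available gives a reason for these results.

Open, on these data alone, is whether an amine or a carboxylic acid in that aromatic place would fall outside the span of compound 1 and compound 2.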